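Shifting the amino group on the benzyl arm

The source may report more compounds than this note shows. Statements on the series, on what has been measured and on what is new or still open speak of the compounds shown alone.

Three compounds share one core and differ only in the group carried on a saturated chain carbon bound to an aromatic nitrogen. Compound 1 `COC(=O)c1ccc(NCc2cncn2Cc2ccccc2C(C)(C)C)cc1-c1ccccc1` has no result in a toxicity assay on NIH3T3 cells (Mus musculus) for cytotoxicity, read by resazurin assay; a higher number here means that more compound is needed for the effect, a lower number that less compound is needed ("not determined" (no result reported)). In this assay compound 2 `COC(=O)c1ccc(NCc2cncn2Cc2cccc(C)c2)cc1-c1ccccc1` reports only a limit, > 10000 nM. Compound 3 `COC(=O)c1ccc(NCc2cncn2Cc2ccc(N)cc2)cc1-c1ccccc1` carries a 4-aminophenyl in place of the 3-methylphenyl of compound 2. In this assay compound 3 likewise reports only a limit, > 10000 nM. The step that the two limits leave unreadable from compound 2 to compound 3 therefore cannot be read. Where compound 3 stands is thus known only as a limit, and the same holds for the other measured compound, as shown by the limit of > 10000 nM in this assay, at which 2 of the 3 values shown sit.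

Compound 4 `COC(=O)c1ccc(NCc2cncn2Cc2ccccc2N)cc1-c1ccccc1` is the next member. Compared with compound 3 the change is 2-aminophenyl in place of 4-aminophenyl on a saturated chain carbon bound to an aromatic nitrogen. For the measured compounds named here, no measured step bears on this change: the only step recorded is the unreadable one from compound 2 to compound 3. What is known is that two of three results sit at the limit, (the limit of > 10000 nM in this assay, at which 2 of the 3 values shown sit).

On that basis compound 4 is expected to sit at the same limit, with an estimate of 15000 nM and a range from 5000 nM to 50000 nM. The step that the limit leaves unreadable from compound 3 to compound 4 is expected to be none beyond the scatter.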

Compound 4, half-maximal effective concentration: 25000 nM
Beside the measured number, compound 4's estimate is 1.7-fold (0.22 log units) below it; low and high end bracket the measured number.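

Compound 2 and compound 3 each report only a limit in this assay, so the steps from either of them to compound 4 cannot be read. The compounds shown leave open whether 2-aminophenyl in place of 4-aminophenyl, or in place of 3-methylphenyl, changes the concentration needed for the effect at all.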